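A few compounds are considered here, and "the series" means these few. Any claim that something is new, unique, unknown or untested is made for them only; others in the source may bear on it.

Measured so far in a functional assay on A2780 cells (Homo sapiens) for antiproliferative activity, read by MTT assay, with a stated time of 3 days; a lower number here means a stronger inhibitor, a higher number a weaker inhibitor:

Compound 1 `CCCCCOC1(c2ccc(Cl)cc2)SC=C(C)n2c1noc2=O` gives > 100000 nM, which is a limit of the assay rather than a number.
Compound 2 `CC/C=C/COC1(c2ccc(Br)cc2)SC=C(C)n2c1noc2=O` gives 59000 nM.

Among the compounds with values here, compound 2 thus stands as the only numbered value in this assay; the other entry, compound 1, sits at the assay limit, as the limit of > 100000 nM in this assay, at which 1 of the 2 values shown sits, records. Within the data shown here, no pair of measured compounds differs in one place, so no measured step is available for this series.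

Compound 3 `CC/C=C/COC1(c2ccc(Cl)cc2)SC=C(C)n2c1noc2=O` differs from compound 2 by chloro in place of bromo on an aromatic carbon. Compound 1 also carries chloro but differs from compound 2 in the chain as well, so its value cannot be read as a step.

For compound 3 the expectation is a step no larger than the scatter, if any, in this assay: a 1.5-fold higher number from compound 2 to compound 3 (0.18 log units; within the scatter). Compound 3 is therefore estimated at 90000 nM, within 35000 nM to 250000 nM, with a fair chance that this assay reports only a limit.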

Compound 3, half-maximal inhibitory concentration: 55000 nM
Beside the measured number, compound 3's estimate is 1.6-fold (0.21 log units) above it; the measured number falls inside the stated range.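

In this assay the change from 4-bromophenyl to 4-chlorophenyl now has a measured size (a 1.1-fold lower number from compound 2 to compound 3 (0.03 log units; within the scatter)), so bromo and chloro cannot be told apart at this position of the series. The chain change has a step as well (an at least 1.8-fold lower number from compound 1 to compound 3 (0.25 log units; that floor lies within the scatter)), but it rests on a limit, and its floor does not separate but-1-en-1-yl from butyl. Compound 1 remains a limit of the assay and not a number: the limit of > 100000 nM in this assay, at which 1 of the 3 values shown sits.

The compounds shown leave open whether anything other than a halogen at this position, such as an amine or a carboxylic acid, would move the number beyond the scatter. Also open, on these data alone, is whether a longer chain in place of but-1-en-1-yl would do so.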